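This account rests on a few compounds, and the source may have more. Where it says the series, first, only, none or still open, it means among the compounds named here.

Measured in a physicochemical assay for lipophilicity; on this read-out higher numbers stand for higher lipophilicity and lower numbers for lower lipophilicity:
- Compound 1 `CCCC[C@H]1CN(c2cccc(C)c2C)C(=O)CN1Cc1cncn1Cc1ccc(C#N)cc1`: > 3.7 (a limit of the assay)
- Compound 2 `N#Cc1ccc(Cn2cncc2CN2CCN(c3cccc(Cl)c3)C(=O)C2=O)cc1`: 1.24

Compound 1 has no exact number in this assay, and its > 3.7 is only a limit. It stands at the limit of > 3.7 in this assay, at which 1 of the 2 values shown sits.

Compound 3 `Cc1cccc(N2CCN(Cc3cncn3Cc3ccc(C#N)cc3)CC2=O)c1C` has not yet been measured. It carries hydrogen in place of butyl on a saturated ring carbon. For the measured compounds named here, no measured step gives the size of this change, so the expectation is a judgement: a clear fall in this assay, beyond the scatter. The expected step is a number at least 1.20 log units lower from compound 1 to compound 3 (beyond the scatter). For compound 3 the estimate is 2.5, with an expected range of 1.9 to 3.1.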

Compound 3, partition coefficient: 2
For compound 3 the middle estimate is 0.50 log units above the measured one; measured number inside the range.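

For the compounds shown here, the first step at this position shows that hydrogen in place of butyl on a saturated ring carbon, with the rest of the core unchanged, gives a number at least 1.70 log units lower from compound 1 to compound 3 (beyond the scatter) in this assay. Compound 1 gives > 3.7, which is a limit of the assay and not a number. From the compounds shown here alone, the full size of the step therefore stays unknown, and only its lower bound can be read: the limit of > 3.7 in this assay, at which 1 of the 3 values shown sits.

The compounds shown leave open how the read-out moves along the series from hydrogen to butyl, with a methyl or a propyl on this carbon. They also leave open what an amine or a hydroxyl on the chain would do.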